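The source may hold more compounds than are shown below. What is called first, only, known or untested is meant among the compounds shown, and "the series" means these compounds.

Compound 1 `O=C(O)c1ccccc1-c1ccc(CCc2ncc(CCC3CCCCC3)[nH]2)cc1` gives 33 nM in an in vitro functional assay on cells for agonist activity at Bombesin receptor subtype-3 (Mus musculus), read by luminescence and calcium flux; a higher number here means that more compound is needed for the effect, a lower number that less compound is needed. Compound 2 `O=C(O)c1ccccc1-c1ccc(CCc2ncc(-c3ccccc3)[nH]2)cc1` gives 872 nM. Compound 3 `COc1cccc(Cc2cnc(CCc3ccc(-c4ccccc4C(=O)O)cc3)[nH]2)c1` gives 79 nM.

Compound 3 stands second of the three, a 2.4-fold higher number from compound 1 to compound 3 (0.38 log units; beyond the scatter), while an 11-fold lower number from compound 2 to compound 3 (1.04 log units; beyond the scatter). Compound 4 `O=C(O)c1ccccc1-c1ccc(CCc2ncc(Cc3ccc(F)cc3)[nH]2)cc1` is not yet measured; it differs from compound 3 by 4-fluorophenyl in place of 3-methoxyphenyl on a saturated chain carbon bound to an aromatic carbon. The two measured steps that touch this position, a 26-fold higher number from compound 1 to compound 2 (1.42 log units; beyond the scatter) and an 11-fold lower number from compound 2 to compound 3 (1.04 log units; beyond the scatter), both exchange a whole group. Among the measured compounds shown here, no measured step swaps one substituent on a benzyl group for another, so the bearing of those steps is indirect. The change is expected to read a 1.3-fold higher number from compound 3 to compound 4 (0.10 log units; within the scatter), within the scatter. Compound 4 is therefore estimated at 100 nM, between 35 nM and 300 nM.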

Compound 4, half-maximal effective concentration: 50 nM
Estimate against measurement, compound 4: 2.0-fold (0.30 log units) above, within the range that was stated.
By their numbers in this assay, from the lowest: compounds 1, 4 and 3 (each within the scatter of the next, the first and the last beyond it); then compound 2.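

Exchanging 3-methoxyphenyl for 4-fluorophenyl on this saturated chain carbon gives a 1.6-fold lower number from compound 3 to compound 4 (0.20 log units; within the scatter), so the two substituted rings cannot be told apart here. Replacing cyclohexylmethyl with 4-fluorophenyl gives a 1.5-fold higher number from compound 1 to compound 4 (0.18 log units; within the scatter), so these two groups cannot be told apart either. Phenyl on the aromatic carbon remains the clear outlier, with 4-fluorobenzyl in its place giving a 17-fold lower number from compound 2 to compound 4 (1.24 log units; beyond the scatter), much as 3-methoxybenzyl did.

On these data alone, whether an amine or a carboxylic acid on this benzyl ring would keep the effect remains open. Nothing available explains why these groups give such similar numbers.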